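An ethyl group added to compound 1

A few compounds are considered here, and "the series" means these few. Any claim that something is new, unique, unknown or untested is made for them only; others in the source may bear on it.

Compound 1 (structure: `Cc1ccc(Cn2c(=O)[nH]c3c(N)nc(-c4ncco4)cc32)cn1`) gives < 7 mL.min-1.g-1 in an in vitro ADME assay on microsomes from liver (Homo sapiens) for metabolic stability (on this read-out higher numbers stand for fast clearance and lower numbers for slow clearance), as a limit, not a number. Compound 2 `Nc1nc(C(F)(F)F)cc2c1[nH]c(=O)n2Cc1ccc(C(F)(F)F)nc1` gives < 7 mL.min-1.g-1 as a limit too. Compound 3 `Nc1ccc(Cn2c(=O)[nH]c3c(N)nc(C(F)(F)F)cc32)cn1` gives < 7 mL.min-1.g-1 as a limit as well. The whole picture therefore rests on the limit of < 7 mL.min-1.g-1 in this assay, at which 3 of the 3 values shown sit, and on no exact number. Compound 4 `CCc1coc(-c2cc3c([nH]c(=O)n3Cc3ccc(C)nc3)c(N)n2)n1` departs from compound 1 by ethyl in place of hydrogen on an aromatic carbon, which turns 1,3-oxazol-2-yl into 4-ethyl-1,3-oxazol-2-yl. Among the measured compounds shown here, the only measured step, a step that the two limits leave unreadable from compound 2 to compound 3, involves other groups and offers no size to carry over. The estimated change is an at least 1.2-fold higher number from compound 1 to compound 4 (0.10 log units; that floor lies within the scatter), a small rise in clearance at most. For compound 4 the expected value is 9 mL.min-1.g-1, within an estimated range of 5 mL.min-1.g-1 to 20 mL.min-1.g-1 in this assay.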

Compound 4, intrinsic clearance in microsomes: < 8 mL.min-1.g-1
Compound 4 ended at the assay's limit (the forecaster's own chance of this, stated with the estimate: 40%); middle value at least 1.1-fold (0.05 log units) from the limit.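

Compound 1 and compound 4 are both reported only as limits in this assay, and the step between them cannot be read. The compounds shown leave open how far adding ethyl shifts clearance, if at all.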